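This account rests on a few compounds, and the source may have more. Where it says the series, first, only, none or still open, it means among the compounds named here.

In a functional assay on HT-29 cells (Homo sapiens) for cytotoxicity, read by MTT assay, with a stated time of 48 h (on this read-out lower numbers stand for stronger inhibition and higher numbers for weaker inhibition), the measured compounds gave the following:

Compound 1 `C#CCOC(=O)Cn1cnc2c1c(=O)n(C)c(=O)n2C`: 68300 nM
Compound 2 `Cn1c(=O)c2c(ncn2CC(=O)NCc2cn(CC3OC(n4ccc(=O)[nH]c4=O)C4OC(C)(C)OC34)nn2)n(C)c1=O`: 58200 nM
Compound 3 `Cn1c(=O)c2c(ncn2CC(=O)OCCc2cn(CC3OC(n4ccc(=O)[nH]c4=O)C4OC(C)(C)OC34)nn2)n(C)c1=O`: 100000 nM

Compound 1 stands second highest of these three numbers. Its nearest neighbour is compound 2, and the gap between them lies within the usual scatter; its furthest neighbour is compound 3, and that gap too lies within the scatter. Among the measured compounds shown here, no step between compounds that differ in only one place is available here.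

Compound 4 `C#CCCOC(=O)Cn1cnc2c1c(=O)n(C)c(=O)n2C` differs from compound 1 in one place: propargyl in place of ethynyl on a saturated chain carbon bound to an oxygen next to a carbonyl group. This is a small lengthening of the chain, and compound 4 is expected to show essentially no step beyond the scatter in this assay, a 1.0-fold higher number from compound 1 to compound 4 (0.01 log units; within the scatter). The estimate for compound 4 is 70000 nM, with a range from 30000 nM to 150000 nM.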

Compound 4, half-maximal inhibitory concentration: 152000 nM
Compound 4: the middle estimate sits 2.2-fold (0.34 log units) below what was measured; measured number outside the range, above it.
By their numbers in this assay, from the lowest: compounds 2, 1, 3 and 4 (each within the scatter of the next, the first and the last beyond it).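

In this assay, the change from propargyl to but-3-yn-1-yl gives a 2.2-fold higher number from compound 1 to compound 4 (0.35 log units; beyond the scatter), a modest step beyond the scatter. Among the compounds shown here, this is the first comparison of compounds that differ in one place, and it shows that the number responds to a small lengthening of the chain at this saturated chain carbon bound to an oxygen next to a carbonyl group. Nothing available here explains the step. As far as these compounds go, whether a longer chain would raise the number further remains open. So does whether an amine or a nitrile at the chain end would lower it.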